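Swapping the aryl group on a piperazine amide

This account rests on a few compounds, and the source may have more. Where it says the series, first, only, none or still open, it means among the compounds named here.

Four compounds share a core in which a five-membered aromatic ring carrying an amide links to a piperazine that bears an aryl group on its other nitrogen. Compound 1, `O=C(c1oc(C(F)(F)F)nc1-c1cccc(F)c1)N1CCN(c2cccc(Cl)c2)CC1`, is recorded as "not active" (no number reported) in a functional assay on HL-60 cells (Homo sapiens) for inhibition, read by MTT assay, with a stated time of 72 h; a higher number here means a weaker inhibitor, a lower number a stronger inhibitor. Compound 2, `Cc1nc(-c2ccccc2)c(C(=O)N2CCN(c3cccc(C(N)=O)c3)CC2)o1`, gives 71 nM in this assay, the lowest of the two numbers reported, while compound 3, `COc1cc(OC)cc(N2CCN(C(=O)c3sc(C)nc3-c3ccccc3F)CC2)c1`, gives 96.8 nM in this assay; the two values lie within the scatter of each other, so they cannot be told apart. Compound 4, `COc1cc(OC)cc(N2CCN(C(=O)c3oc(C)nc3-c3ccccc3)CC2)c1`, has not yet been measured. It differs from compound 2 by 3,5-dimethoxyphenyl in place of 3-carbamoylphenyl on an amine nitrogen in a ring. Compound 3 already carries the same 3,5-dimethoxyphenyl group on its piperazine nitrogen and gives a number close to that of compound 2, although compound 3 also differs in the five-membered ring and in a fluorine on the other phenyl ring. Among the measured compounds shown here, no measured step isolates this single change. The step from compound 2 to compound 4 is therefore expected to stay within the scatter, with no clear direction, giving a 1.2-fold higher number from compound 2 to compound 4 (0.08 log units; within the scatter). For compound 4 the estimate in this assay is 85 nM, with a range from 30 nM to 250 nM.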

Compound 4, half-maximal inhibitory concentration: 19.2 nM
Compound 4: the middle estimate sits 4.4-fold (0.65 log units) above what was measured; the whole stated range lies above it.
By their numbers in this assay, from the lowest: compound 4; then compounds 2 and 3 (each within the scatter of the next).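

Among the compounds shown here, this is the first pair here that differs in one place only, so it shows on its own that the aryl group on the amine nitrogen in a ring matters to the number in this assay. With the rest of compound 2 held constant, 3,5-dimethoxyphenyl in place of 3-carbamoylphenyl gives a 3.7-fold lower number from compound 2 to compound 4 (0.57 log units; beyond the scatter) and so yields the stronger inhibitor of the pair, a modest step but one beyond the usual scatter. The entering group has no hydrogen-bond donor and one more hydrogen-bond acceptor than the group it replaces, but no measurement here links those counts, or anything else, to the step.

Still open, going by these compounds, is whether both methoxy groups are needed, or whether a single methoxy group, an amine or a carboxylic acid on the same phenyl ring would give a similar number. Also open, on these data alone, is whether the same swap would give a step of similar size on a core carrying a trifluoromethyl group, as the core of compound 1 does, or on the different five-membered ring of compound 3.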